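Swapping Chloro for Trifluoromethyl on the 4-Chlorophenyl Group

The compounds below may be only part of what the source reports. "The series", "measured", "known", "first", "only" and "open" are said of these compounds alone.

- compound 1 `COc1cc(-c2nc(-c3ccccc3)[nH]c2-c2ccnc(NCCCNS(=O)(=O)c3ccc(Cl)cc3)n2)ccc1F`: 83100 nM
- compound 2 `COc1cc(-c2nc(-c3ccccc3)[nH]c2-c2ccnc(NCCCNS(=O)(=O)c3ccc(Br)cc3)n2)ccc1F`: 33900 nM
- compound 3 `COc1cc(-c2nc(-c3ccccc3)[nH]c2-c2ccnc(NCCCNS(=O)(=O)c3ccc(Cl)cc3)n2)ccc1Cl`: 60900 nM

These values come from a functional assay on LOX IMVI cells (Homo sapiens) for cytotoxicity, read by MTT assay, with a stated time of 24 h; a lower number here means a stronger inhibitor, a higher number a weaker inhibitor. Compound 3, at 60900 nM, lies within the usual scatter of both neighbours, compound 1 at 83100 nM and compound 2 at 33900 nM, so its place among the three is not firmly fixed.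

Compound 4 `COc1cc(-c2nc(-c3ccccc3)[nH]c2-c2ccnc(NCCCNS(=O)(=O)c3ccc(C(F)(F)F)cc3)n2)ccc1Cl` differs from compound 3 in one place, (trifluoromethyl in place of chloro on an aromatic carbon). In words, trifluoromethyl takes the place of chloro on an aromatic carbon, turning 4-chlorophenyl into 4-(trifluoromethyl)phenyl.

Two measured steps offer some guidance. The closer one is a 2.5-fold lower number from compound 1 to compound 2 (0.39 log units; beyond the scatter), which also replaces the chloro of the 4-chlorophenyl group, here with bromo. The other, a 1.4-fold lower number from compound 1 to compound 3 (0.13 log units; within the scatter), changes a different group, fluoro to chloro, and so bears less directly on this swap. Within the data shown here, no measured compound carries trifluoromethyl, so the data cannot settle the direction, and the one relevant swap was modest in size. No change beyond the scatter is therefore expected in this assay.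

The step expected here is a 1.2-fold lower number from compound 3 to compound 4 (0.09 log units; within the scatter). The estimate for compound 4 is 50000 nM, with an expected range from 20000 nM to 110000 nM.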

Compound 4, half-maximal inhibitory concentration: 1780 nM
For compound 4 the middle estimate is 28-fold (1.45 log units) above the measured one; the measured number lies below the stated range.
By their numbers in this assay, from the lowest: compound 4; then compounds 2, 3 and 1 (each within the scatter of the next, the first and the last beyond it).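

In this assay, replacing chloro with trifluoromethyl on the 4-chlorophenyl group gives a 34-fold lower number from compound 3 to compound 4 (1.53 log units; beyond the scatter), a far larger response at this position than the earlier exchange of chloro for bromo, a 2.5-fold lower number from compound 1 to compound 2 (0.39 log units; beyond the scatter), suggested. The earlier compounds shown here showed this end of the molecule tolerating a halogen swap with only a modest shift, whereas this result shows that the group at this position can strongly change the cytotoxicity read-out, even though the change adds no hydrogen-bond donor, hydrogen-bond acceptor or net charge and only replaces 1 heavy atom with 4. No measurement shown here accounts for the size of this step.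

On these data alone, whether the large step also appears with fluoro in place of chloro on the methoxy-bearing ring remains open, as the trifluoromethyl group appears here only alongside chloro. Also unresolved is whether the response is particular to trifluoromethyl or would extend to other groups at this position, such as a nitrile, a methyl group, an amine or a carboxylic acid.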